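This account rests on a few compounds, and the source may have more. Where it says the series, first, only, none or still open, it means among the compounds named here.

Compound 1, `C#CCNc1nc(-c2ccccc2)c(Cc2c(O)ccc3ccccc23)c(=O)[nH]1`, gives 130000 nM in a functional assay on RT-112 cells (Homo sapiens) for antiproliferative activity, read by MTT assay, with a stated time of 24 h; on this read-out higher numbers stand for weaker inhibition and lower numbers for stronger inhibition.
Compound 2, `O=c1[nH]c(NCCO)nc(-c2ccccc2)c1Cc1c(O)ccc2ccccc12`, gives 96600 nM in this assay.

Both measured numbers are large, meaning weak inhibition. Compound 2 and compound 1 differ only by a 1.3-fold lower number from compound 1 to compound 2 (0.13 log units; within the scatter), which lies within the scatter, so neither stands apart from the other; compound 2 simply holds the smaller of the two numbers.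

Compound 3, `O=c1[nH]c(Nc2ccc(O)cc2)nc(-c2ccccc2)c1Cc1c(O)ccc2ccccc12`, carries 4-hydroxyphenyl in place of 2-hydroxyethyl on a nitrogen on an aromatic ring. Cut one bond further out, this reads as (2-hydroxyethyl)amino becoming (4-hydroxyphenyl)amino: an open chain gives way to a six-membered aromatic ring of carbon only, while one hydrogen-bond donor and one acceptor are kept.

Going by the values given here, only one measured step touches the same nitrogen, a 1.3-fold lower number from compound 1 to compound 2 (0.13 log units; within the scatter), and it swapped one small chain for another without moving beyond the scatter. Among the compounds with values here, no measured step replaces a chain with a ring here, so the present change is unanchored. The expectation for compound 3 is therefore a step of a 1.2-fold lower number from compound 2 to compound 3 (0.08 log units; within the scatter) in this assay, with little confidence in its direction. Compound 3 is estimated at 80000 nM, within a range from 25000 nM to 250000 nM.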

Compound 3, half-maximal inhibitory concentration: 265000 nM
The estimate for compound 3 lay 3.3-fold (0.52 log units) below the measured number; the measured number lies above the stated range.
By their numbers in this assay, from the lowest: compounds 2 and 1 (each within the scatter of the next); then compound 3.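

Going by these compounds alone, at the nitrogen on the aromatic ring, replacing an open chain with a ring produces the first change beyond the scatter: in this assay, 4-hydroxyphenyl in place of 2-hydroxyethyl gives a 2.7-fold higher number from compound 2 to compound 3 (0.44 log units; beyond the scatter), and 4-hydroxyphenyl in place of propargyl gives a 2.0-fold higher number from compound 1 to compound 3 (0.31 log units; beyond the scatter). Both steps are modest and point the same way, so compound 3 shows weaker inhibition than either chain-bearing compound, whereas the two chains remain within the scatter of each other. 2-hydroxyethyl and 4-hydroxyphenyl carry the same counts of hydrogen-bond donors and acceptors. The step to compound 3 leaves those counts untouched and still lies beyond the scatter, even though all three numbers remain large.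

No evidence at hand explains why the ring goes with the higher number. The compounds shown leave open whether that higher number follows the ring itself or the hydroxyl on it, a question that a plain phenyl group on the same nitrogen would help to settle.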